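The source may report more compounds than this note shows. Statements on the series, on what has been measured and on what is new or still open speak of the compounds shown alone.

Of the compounds shown here, three measured so far share a core, and a fourth, built by the same kind of small addition already seen once among them, is the open question. Compound 3 `COc1ccc(-c2cc(/C=C/C(=O)c3ccc(N)cc3)[nH]n2)cc1OC` is the plainest of the three. In a functional assay on SN12C cells (Homo sapiens) for inhibition, read by sulforhodamine B assay, with a stated time of 48 h (on this read-out higher numbers stand for weaker inhibition of growth and lower numbers for stronger inhibition of growth), compound 3 gives 3530 nM. Compound 1 `COc1cc(-c2cc(/C=C/C(=O)c3ccc(N)cc3)[nH]n2)cc(OC)c1OC` carries one extra group, described as methoxy in place of hydrogen on an aromatic carbon, and in this assay compound 1 gives 1860 nM; the step recorded is a 1.9-fold lower number from compound 3 to compound 1 (0.28 log units; within the scatter). Compound 2 `COc1ccc(C(=O)/C=C/c2cc(-c3cc(OC)c(OC)c(OC)c3)n[nH]2)cc1OC` replaces the 4-aminophenyl of compound 1 with 3,4-dimethoxyphenyl on the carbonyl carbon, and in this assay compound 2 gives 1540 nM, so the step is a 1.2-fold lower number from compound 1 to compound 2 (0.08 log units; within the scatter). Going by the values given here, compound 2 holds the lowest of the three numbers, but only its distance from compound 3 lies beyond the usual scatter, so no strongest compound can be named.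

Compound 4 `COc1cc(C(=O)/C=C/c2cc(-c3cc(OC)c(OC)c(OC)c3)n[nH]2)cc(OC)c1OC` has not been measured. It differs from compound 2 by methoxy in place of hydrogen on an aromatic carbon, which is the same change that turned compound 3 into compound 1, with the same surroundings. How the cores of compound 2 and compound 3 differ is not broken down here. Because that earlier step was a 1.9-fold lower number from compound 3 to compound 1 (0.28 log units; within the scatter), the step from compound 2 to compound 4 is expected to be of similar modest size, a 1.5-fold lower number from compound 2 to compound 4 (0.19 log units; within the scatter), and to stay within the scatter. Compound 4 is therefore estimated in this assay at 1000 nM, with a likely range from 450 nM to 2500 nM.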

Compound 4, concentration for 50% growth inhibition: 1470 nM
The estimate for compound 4 lay 1.5-fold (0.17 log units) below the measured number; low and high end bracket the measured number.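

In this assay, the step reads a 1.0-fold lower number from compound 2 to compound 4 (0.02 log units; within the scatter), so adding this methoxy group leaves compound 2 and compound 4 indistinguishable. The same change on the other core gave a step of similar size, and the gap between the two steps is no larger than repeated measurements of this kind would produce: the same change on two cores in this assay, a 1.9-fold lower number (0.28 log units; within the scatter) from compound 3 to compound 1 and a 1.0-fold lower number (0.02 log units; within the scatter) from compound 2 to compound 4, 1.8-fold (0.26 log units) apart, within the scatter of two such steps. This shows that the two cores give no detectable disagreement over this change, but it does not show that the methoxy group itself alters growth inhibition, since each step lies within the scatter, and a pair of cores cannot establish a rule for the whole series.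

The compounds shown compare only methoxy with hydrogen at this place on the aromatic ring, so it remains open whether a hydroxyl group, a chlorine atom or a longer chain such as ethoxy would produce a step beyond the scatter. On these data alone, it also remains open whether the methoxy change would behave in the same way on a core other than these two.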